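The source may report more compounds than this note shows. Statements on the series, on what has been measured and on what is new or still open speak of the compounds shown alone.

Three compounds have been measured in a functional assay on PC-3 cells (Homo sapiens) for cytotoxicity, read by MTT assay, with a stated time of 48 h; on this read-out higher numbers stand for weaker inhibition and lower numbers for stronger inhibition:
compound 1, `CC1=NN(C(=O)CCc2ccccc2)C(c2cc(Br)ccc2O)C1`, giving 16300 nM
compound 2, `CC1=NN(S(=O)(=O)c2ccc(C)cc2)C(c2cc(Br)ccc2O)C1`, giving 33200 nM
compound 3, `Cc1ccc(C(=O)N2N=C(c3cc4ccccc4oc3=O)CC2c2ccccc2)cc1`, giving 13200 nM

Compound 3 carries the lowest of the three numbers, but its gap to compound 1 lies within the usual scatter, so no order can be read between those two; only the gap to compound 2 lies beyond the scatter. Compound 4, `CC1CCCCN1CC(=O)N1N=C(c2cc3ccccc3oc2=O)CC1c1ccccc1`, differs from compound 3 in one place: (2-methylpiperidin-1-yl)methyl in place of 4-methylphenyl on a carbonyl carbon. Going by the values given here, no measured pair shows a change of this kind, so there is no measured step to lean on. The step from compound 3 to compound 4 is expected to be small, with no direction beyond the scatter, a 1.0-fold lower number from compound 3 to compound 4 (0.01 log units; within the scatter). In this assay compound 4 is estimated at 13000 nM, within a range from 4000 nM to 45000 nM.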

Compound 4, half-maximal inhibitory concentration: 36300 nM
Compound 4: middle estimate off by 2.8-fold (0.45 log units), on the low side, within the range that was stated.
By their numbers in this assay, from the lowest: compounds 3 and 1 (each within the scatter of the next); then compounds 2 and 4 (each within the scatter of the next).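

Replacing 4-methylphenyl with (2-methylpiperidin-1-yl)methyl on the carbonyl carbon gives, in this assay, a 2.8-fold higher number from compound 3 to compound 4 (0.44 log units; beyond the scatter). Going by these compounds alone, this is the first measured change at this position, and it shows that the position responds to the group it carries: here, the non-aromatic ring holding a nitrogen gives weaker inhibition than the aromatic ring. Nothing measured here explains this step.

The compounds shown leave open whether the ring nitrogen, the loss of the aromatic ring or the added methylene matters. Cyclohexylmethyl or benzyl on the same carbonyl carbon would help separate these.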